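Diazepane to aminopiperidine swap on the pyrimidine amine

A few compounds are considered here, and "the series" means these few. Any claim that something is new, unique, unknown or untested is made for them only; others in the source may bear on it.

Among the measured compounds shown here, compound 2 `Cc1nc(CN2CCC[C@H]2c2ncccc2C)cc(N2CCCN(C)CC2)n1` is the only member of the series with a number: in a functional assay on cells (T cell) for antagonist activity at C-X-C chemokine receptor type 4 (Homo sapiens), read by FLIPR and calcium flux, with a stated time of 20 min (on this read-out lower numbers stand for stronger inhibition and higher numbers for weaker inhibition), compound 2 gives 0.4 nM. Compound 1 `Cc1cccc([C@@H]2CCCN2Cc2cc(N3CCN(C)CC3)nc(C)n2)n1` in this assay shows "not determined" (no result reported), so no comparison is possible there. Compound 3 `Cc1nc(CN2CCC[C@H]2c2ncccc2C)cc(N2CCC(N(C)C)CC2)n1` carries 4-(dimethylamino)piperidin-1-yl in place of 4-methyl-1,4-diazepan-1-yl on an aromatic carbon; the remainder of the shared core is unchanged. For the measured compounds named here, no measured step covers this change, so the size must be guessed: a small loss in this assay is expected, probably not beyond the scatter, as a 2.5-fold higher number from compound 2 to compound 3 (0.40 log units; beyond the scatter). Compound 3 is therefore estimated at 1 nM in this assay, within 0.3 nM to 4 nM.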

Compound 3, half-maximal inhibitory concentration: 13 nM
The estimate for compound 3 lay 13-fold (1.11 log units) below the measured number; the whole stated range lies below it.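

On this aromatic carbon the amine is not freely exchangeable in this assay: 4-(dimethylamino)piperidin-1-yl in place of 4-methyl-1,4-diazepan-1-yl gives a 33-fold higher number from compound 2 to compound 3 (1.51 log units; beyond the scatter), a large loss. Among the compounds shown here, this is the first measured step at this position, and it comes with the counted hydrogen-bond acceptors and the net charge unchanged. Nothing available accounts for the size of this step.

Open, going by these compounds, is whether the loss follows from the ring or from the dimethylamino group. A morpholine or a 4-aminopiperidine at this carbon would help to separate the two.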